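Compound 4 and the step from ester to acid

The source may hold more compounds than are shown below. What is called first, only, known or untested is meant among the compounds shown, and "the series" means these compounds.

compound 1 `C=C(CCCC)C(=O)c1ccc(OC(C)C(=O)O)c(C)c1C` gives 12100 nM
compound 2 `C=C(CCCC)C(=O)c1ccc(OC(C)C(=O)OC)c(C)c1C` gives 5200 nM
compound 3 `C=C(CCC)C(=O)c1ccc(OC(C)C(=O)OC)c(C)c1C` gives 5600 nM

In a functional assay on HL-60 cells (Homo sapiens) for antiproliferative activity, with a stated time of 72 h (a higher number here means a weaker inhibitor of growth, a lower number a stronger inhibitor of growth), compound 3 stands at 5600 nM and sits level with compound 2, which reads 5200 nM within the scatter. Compound 1, at 12100 nM on the same read-out, has the highest number of the three and lies beyond the scatter from both.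

Compound 4 `C=C(CCC)C(=O)c1ccc(OC(C)C(=O)O)c(C)c1C` carries one change from compound 3 (hydrogen in place of methyl on an oxygen next to a carbonyl group) with hydrogen in place of methyl on an oxygen next to a carbonyl group, so that methoxycarbonyl becomes carboxy.

For the measured compounds named here, two measured steps bear on this change. The same swap, run the other way, gave a 2.3-fold lower number from compound 1 to compound 2 (0.37 log units; beyond the scatter) when methyl replaced hydrogen, a modest step. The change in the chain gave a 1.1-fold higher number from compound 2 to compound 3 (0.03 log units; within the scatter) and so offers no reason to expect the swap to behave differently on compound 3. Going by the values given here, a step of similar size is therefore expected, this time upward towards weaker inhibition of growth, although only one pair supports it. The estimated step is a 2.2-fold higher number from compound 3 to compound 4 (0.35 log units; beyond the scatter) and it carries that uncertainty. Compound 4 is estimated at 12500 nM with an expected range from 7500 nM to 21000 nM in this assay once measured.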

Compound 4, concentration for 50% growth inhibition: 11200 nM
For compound 4 the middle estimate is 1.1-fold (0.05 log units) above the measured one; the range from low to high includes it.
By their numbers in this assay, from the lowest: compounds 2, 3, 4 and 1 (each within the scatter of the next, the first and the last beyond it).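

In this assay, the change from methoxycarbonyl to carboxy can now be read on a second core. Taken alone, a 2.0-fold higher number from compound 3 to compound 4 (0.30 log units; within the scatter) stays within the scatter, yet it runs in the same direction and is close in size to the step on the first core: the same change on two cores in this assay, a 2.3-fold lower number (0.37 log units; beyond the scatter) from compound 1 to compound 2 and a 2.0-fold lower number (0.30 log units; within the scatter) from compound 4 to compound 3, 1.2-fold (0.07 log units) apart, within the scatter of two such steps. The chain change can also now be read on the acids as well as the methyl esters, where a 1.1-fold lower number from compound 1 to compound 4 (0.03 log units; within the scatter) adds a second small step, so the shorter and longer chains cannot be told apart in either series: the same change on two cores in this assay, a 1.1-fold higher number (0.03 log units; within the scatter) from compound 2 to compound 3 and a 1.1-fold lower number (0.03 log units; within the scatter) from compound 1 to compound 4, 1.2-fold (0.07 log units) apart, within the scatter of two such steps. Across these four compounds, the group on the oxygen next to the carbonyl group therefore tracks the numbers more closely than the chain does, although the pair compound 3 and compound 4 alone does not clear the scatter.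

The compounds shown leave open how an ethyl ester or a primary amide would read in place of the methyl ester or the carboxy group. They also leave open whether a much longer chain, such as octyl, or a branched chain would read level with the chains seen here.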